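The source may report more compounds than this note shows. Statements on the series, on what has been measured and on what is new or still open speak of the compounds shown alone.

Three compounds share one core and differ only in the group attached to the carbonyl carbon. Compound 1 `O=C(NC1CCN(c2ncnc3[nH]ncc23)CC1)c1cccc(C(F)(F)F)c1` is the strongest inhibitor of the set; in an assay on isolated protein for inhibition of serine/threonine-protein kinase PAK 1 (Homo sapiens), read by ADP-Glo, with a stated time of 40 min (a higher number here means a weaker inhibitor, a lower number a stronger inhibitor), compound 1 gives 2510 nM. Compound 2 `O=C(NC1CCN(c2ncnc3[nH]ncc23)CC1)c1ccccc1Cl` gives 5240 nM in this assay, the second highest of the three numbers: its gap to compound 1 lies beyond the scatter, while compound 3 `O=C(Nc1ccc(C(F)(F)F)cc1)NC1CCN(c2ncnc3[nH]ncc23)CC1`, with 7150 nM in this assay, sits within the scatter of compound 2, so no order between compound 2 and compound 3 can be claimed.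

Compound 4 `O=C(Nc1cccc(Cl)c1)NC1CCN(c2ncnc3[nH]ncc23)CC1` has not yet been measured. It differs from compound 2 by (3-chlorophenyl)amino in place of 2-chlorophenyl on a carbonyl carbon. Among the measured compounds shown here, no measured pair shows this exact change on its own, so the size of the step can only be guessed. Since compound 3 gives 7150 nM and compound 2 gives 5240 nM, a change of this kind is expected to move the number little, with the step of a 1.1-fold higher number from compound 2 to compound 4 (0.06 log units; within the scatter) estimated to stay within the scatter. Compound 4 is therefore expected to give about 6000 nM in this assay, with a range from 2500 nM to 15000 nM.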

Compound 4, half-maximal inhibitory concentration: 1240 nM
For compound 4 the middle estimate is 4.8-fold (0.68 log units) above the measured one; the whole stated range lies above it.
By their numbers in this assay, from the lowest: compound 4; then compound 1; then compounds 2 and 3 (each within the scatter of the next).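

Swapping 2-chlorophenyl for (3-chlorophenyl)amino on this carbonyl carbon gives a 4.2-fold lower number from compound 2 to compound 4 (0.63 log units; beyond the scatter) and so shows that this position can move the number further than the earlier compounds did. The added amino nitrogen does not ensure a low number by itself: compound 3 also has an aryl-bearing amino group on this carbonyl carbon and gives 7150 nM in this assay while compound 4 gives 1240 nM in the same test. The data offer no measured explanation for the lower number of compound 4.

As far as these compounds go, this step changes both the amino nitrogen and the place of the chlorine, so the share of each remains unknown. From the compounds shown here alone, the same carbonyl carbon bearing (2-chlorophenyl)amino or 3-chlorophenyl would separate the two changes, and the effect of replacing the chlorine with a nitrile or a methoxy group also remains open.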